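A Methyl Step from Compound 1

The source may hold more compounds than are shown below. What is called first, only, known or untested is meant among the compounds shown, and "the series" means these compounds.

In a functional assay on RS4-11 cells (Homo sapiens) for inhibition, read by CCK-8 assay, with a stated time of 48 h (a lower number here means a stronger inhibitor, a higher number a weaker inhibitor), compound 1 (`O=C(NCCNS(=O)(=O)c1sccc1-c1ccccc1Oc1ccc(O)c(O)c1)Nc1cc(Cl)cc(Cl)c1`) gives 6200 nM and compound 2 (`CC(C)c1ccc(Oc2ccc(O)c(O)c2)c(-c2ccsc2S(=O)(=O)NCCNC(=O)Nc2cc(Cl)cc(Cl)c2)c1`) gives 6400 nM within the scatter of it, so the two stand level. Compound 3 (`Cc1ccc(-c2ccsc2S(=O)(=O)NCCNC(=O)Nc2cc(Cl)cc(Cl)c2)c(Oc2ccc(O)c(O)c2)c1`) differs from compound 1 by methyl in place of hydrogen on an aromatic carbon in one place, methyl in place of hydrogen on an aromatic carbon. For the measured compounds named here, the only measured step that bears on this is isopropyl in place of hydrogen on an aromatic carbon, a 1.0-fold higher number from compound 1 to compound 2 (0.01 log units; within the scatter) and within the scatter. No change beyond the scatter is therefore expected in this assay and the estimated step is a 1.0-fold lower number from compound 1 to compound 3 (0.01 log units; within the scatter) in size. Compound 3 is expected at 6000 nM (estimated range 2500 nM to 14000 nM).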

Compound 3, half-maximal inhibitory concentration: 5100 nM
Compound 3: middle estimate off by 1.2-fold (0.07 log units), on the high side, within the range that was stated.
By their numbers in this assay, from the lowest: compounds 3, 1 and 2 (each within the scatter of the next).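

In this assay, a methyl on this carbon, meta to a 3,4-dihydroxyphenoxy group and para to a large group, leaves the number level (a 1.2-fold lower number from compound 1 to compound 3 (0.08 log units; within the scatter)). For the compounds shown here, compound 2 carries its isopropyl on a different carbon of the same ring, so this is the first reading at this position, and it shows that the position accepts one added carbon without a change beyond the scatter. Nothing available explains this result. From the compounds shown here alone, whether an amine, a carboxylic acid or a longer chain on this carbon would also leave the number level remains open.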